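This account rests on a few compounds, and the source may have more. Where it says the series, first, only, none or still open, it means among the compounds named here.

Three compounds have been measured in a functional assay on HepG2 cells (Homo sapiens) for antiproliferative activity, read by MTT assay, with a stated time of 72 h; a higher number here means a weaker inhibitor, a lower number a stronger inhibitor:

Compound 1 `CC(C)(C)c1cn(C[C@H](O)[C@H]2OC(=O)C(OCc3ccccc3)=C2OCc2ccccc2)nn1` gives 29200 nM.
Compound 2 `O=C1O[C@H]([C@@H](O)Cn2cc(CNS(=O)(=O)c3ccc(Cl)cc3F)nn2)C(OCc2ccccc2)=C1OCc1ccccc1` gives 25500 nM.
Compound 3 `COc1ccc(-c2cn(C[C@H](O)[C@H]3OC(=O)C(OCc4ccccc4)=C3OCc3ccccc3)nn2)cc1` gives 46400 nM.

Compound 3 gives the highest number of the three, yet its separation from compound 1 and from compound 2 is within the scatter, so the three compounds cannot be told apart in this assay. Among the compounds with values here, the one single-point step among them is a 1.6-fold higher number from compound 1 to compound 3 (0.20 log units; within the scatter), a change at the same aromatic carbon of the five-membered ring that is now altered again, and it made no difference beyond the scatter. Compound 2, which carries a larger and quite different substituent at that position, also sits within the scatter of the other two.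

Compound 4 `O=C1O[C@H]([C@@H](O)Cn2cc(CCCCl)nn2)C(OCc2ccccc2)=C1OCc1ccccc1` is the next compound to be measured. Compared with compound 3 it carries 3-chloropropyl in place of 4-methoxyphenyl on an aromatic carbon. Within the data shown here, the only measured step that bears on this change is the one from compound 1 to compound 3, and it was within the scatter; no measured pair shows that what sits at this position moves the number. Compound 4 is therefore expected to show a step of a 1.5-fold lower number from compound 3 to compound 4 (0.16 log units; within the scatter), meaning no movement beyond the scatter. Compound 4 is estimated at 32000 nM, with a range from 14000 nM to 75000 nM.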

Compound 4, half-maximal inhibitory concentration: 35000 nM
Compound 4: middle estimate off by 1.1-fold (0.04 log units), on the low side, within the range that was stated.
By their numbers in this assay, from the lowest: compounds 2, 1, 4 and 3 (each within the scatter of the next).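

In this assay, putting 3-chloropropyl in place of 4-methoxyphenyl on the aromatic carbon of the five-membered ring gives a 1.3-fold lower number from compound 3 to compound 4 (0.12 log units; within the scatter), and putting it in place of tert-butyl gives a 1.2-fold higher number from compound 1 to compound 4 (0.08 log units; within the scatter), so a chain with no ring now joins an aromatic ring and a compact branched group without any separation beyond the scatter. The comparison with the sulfonamide compound points the same way: 2-chloroethyl in place of ((4-chloro-2-fluorophenyl)sulfonyl)amino on the saturated chain carbon gives a 1.4-fold higher number from compound 2 to compound 4 (0.14 log units; within the scatter), so removing that large substituent also leaves the number within the scatter. No measurement available here explains why these different groups cannot be told apart.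

The four compounds leave open whether any group at this carbon can move the number beyond the scatter, for instance a chain ending in an amine or a carboxylic acid, or a much longer chain. They also leave open whether a change elsewhere on the shared core would have a larger effect, since all four compounds differ only at this one place.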